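Removing a Methyl from an Aromatic Oxygen: a Fourth Compound

This account rests on a few compounds, and the source may have more. Where it says the series, first, only, none or still open, it means among the compounds named here.

Measured in a functional assay on HL-60 cells (Homo sapiens) for antiproliferative activity; on this read-out lower numbers stand for stronger inhibition and higher numbers for weaker inhibition:
Compound 1, `Cc1ccc(O)c2c(O)ccnc12`, gives > 30000 nM, which is a limit of the assay and not a number.
Compound 2, `COc1ccc(C)c2nccc(O)c12`, gives > 30000 nM, again a limit.
Compound 3, `COc1cc(C(F)(F)F)cc2nccc(O)c12`, gives > 30000 nM, also a limit.

All three sit at the limit of > 30000 nM in this assay, at which 3 of the 3 values shown sit, so none of them shows inhibition that this assay can put a number on. From compound 2 to compound 1 the change is hydrogen in place of methyl on an oxygen on an aromatic ring, and the step it made is a step that the two limits leave unreadable from compound 2 to compound 1. Compound 4, `Oc1ccnc2cc(C(F)(F)F)cc(O)c12`, has not yet been measured in this assay; it differs from compound 3 by hydrogen in place of methyl on an oxygen on an aromatic ring, the same change in the same place. How the core of compound 3 differs from the core of compound 2 is not broken down here. The step expected for the new pair is a number no higher from compound 3 to compound 4 (the limit leaves the size open), resting on the unreadable earlier step and on the three limits. Compound 4 is therefore expected to give about 30000 nM, somewhere between 8000 nM and 100000 nM, most likely again only a limit, because its nearest measured relatives all sit at the limit of > 30000 nM in this assay, at which 3 of the 3 values shown sit.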

Compound 4, half-maximal inhibitory concentration: > 30000 nM
Compound 4: a limit, no number (the forecaster's own chance of this, stated with the estimate: 80%); the middle value sits exactly at the limit.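

Compound 3 and compound 4 both give only a limit of the assay and not a number, so no step can be read for the change from methoxy to hydroxy between them: the limit of > 30000 nM in this assay, at which 4 of the 4 values shown sit.

The compounds shown leave open whether this change affects inhibition at all, and which structural change, if any, would give a value that can be read as a number.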